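Compound 3 to compound 4: 2-ethoxyethyl to isobutyl

A few compounds are considered here, and "the series" means these few. Any claim that something is new, unique, unknown or untested is made for them only; others in the source may bear on it.

Values measured in an ADME assay on microsomes from liver (Mus musculus) for metabolic stability, read by LC-MS, using NADPH, tested at 4.6 uM (on this read-out higher numbers stand for a longer-lived compound and lower numbers for a shorter-lived compound), are as follows
Compound 1 `O=C(NCCCCc1ccccc1)n1cc(-c2ccccc2)oc1=O` gives 0.667 h
Compound 2 `CCCCCNC(=O)n1cc(-c2ccccc2)oc1=O` gives < 0.0834 h as a limit
Compound 3 `CCOCCNC(=O)n1cc(-c2ccccc2)oc1=O` gives < 0.0834 h as a limit

Compound 3 has no number here, only the limit < 0.0834 h as its value. That places it at the limit of < 0.0834 h in this assay, at which 2 of the 3 values shown sit, and nowhere more exact.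

Compound 4 `CC(C)CNC(=O)n1cc(-c2ccccc2)oc1=O` differs from compound 3 by isopropyl in place of ethoxymethyl on a saturated chain carbon bound to an amide-type nitrogen. Cut one bond further out, the same difference reads 2-ethoxyethyl to isobutyl.

The nearest measured comparison is a step that the two limits leave unreadable from compound 2 to compound 3 and so gives no size to carry over. Larger movement appears only in an at least 7.9-fold lower number from compound 1 to compound 2 (0.90 log units; beyond the scatter) and in an at least 7.9-fold lower number from compound 1 to compound 3 (0.90 log units; beyond the scatter) and both lie beyond the scatter, yet each takes away a phenyl group, which the present change does not. With no ring entering or leaving, the expectation is a step that the limit leaves unreadable from compound 3 to compound 4 and no step beyond the scatter is expected in this assay in either direction. For compound 4 the estimated half-life is 0.07 h with an expected range from 0.03 h to 0.2 h and a report as a limit is likely.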

Compound 4, half-life: 0.833 h
Compound 4: the middle estimate sits 12-fold (1.08 log units) below what was measured, and the stated range ends below it.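

In this assay, the isobutyl chain gives an at least 9.9-fold higher number from compound 3 to compound 4 (0.99 log units; beyond the scatter) and an at least 9.9-fold higher number from compound 2 to compound 4 (0.99 log units; beyond the scatter), so a change on a saturated chain carbon bound to an amide-type nitrogen can move the half-life beyond the scatter with no phenyl group entering or leaving. A phenyl group on the chain is therefore not needed for a half-life that can be read as a number: compound 4 carries no ring on its chain and gives 0.833 h, while compound 1, with its phenyl-ended chain, gives 0.667 h. Compound 2 and compound 3 stand only as limits, so the true size of both new steps stays open and the step between those two compounds cannot be read: the limit of < 0.0834 h in this assay, at which 2 of the 4 values shown sit.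

The compounds shown do not separate the branching of the isobutyl chain from its length, as isopropyl takes the place of butyl in a single step. Going by these compounds, how a tert-butyl group, a cyclopropylmethyl group or a chain ending in an amine or a carboxylic acid would behave at this place also remains open.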